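Urea Change on the Shared Core and Receptor Binding

This account rests on a few compounds, and the source may have more. Where it says the series, first, only, none or still open, it means among the compounds named here.

Measured compounds:
Compound 1 `Cc1cc(C)cc(CN(C)C(=O)c2c(-c3ccccc3C)c3ccccc3c(=O)n2C)c1` gives 32 nM in an assay on IM-9 cells for binding affinity to Substance-P receptor (Homo sapiens); a lower number here means a stronger inhibitor, a higher number a weaker inhibitor.
Compound 2 `Cc1cc2c(-c3ccccc3)c(NC(=O)N(C)Cc3ccccc3Cl)n(C)c(=O)c2cc1C` gives 4.2 nM in this assay.
Compound 3 `COc1ccccc1CN(C)C(=O)c1c(-c2ccccc2)c2ccccc2c(=O)n1C` gives 30 nM in this assay.

Among the three, compound 2 has the lowest number in this assay. Its nearest neighbour is compound 3, whose value stands beyond the scatter above it, and compound 1 stands further still, also beyond the scatter. Compound 2 is therefore the strongest binder of the set that has been measured.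

Compound 4 `Cc1cccc(NC(=O)Nc2c(-c3ccccc3)c3cc(C)c(C)cc3c(=O)n2C)c1` has not yet been measured in this assay. It keeps the core of compound 2 and differs only at the urea: a group of 8 heavy atoms (7 carbon, 1 nitrogen; one six-membered aromatic ring of carbon only) in place of a group of 10 heavy atoms (8 carbon, 1 nitrogen, 1 chlorine; one six-membered aromatic ring of carbon only), on a carbonyl carbon. The N-methyl and the 2-chlorobenzyl group leave together, and a (3-methylphenyl)amino group with one hydrogen-bond donor enters.

Going by the values given here, no step between measured compounds shows what such a change does. Compounds 1 and 3, which carry a methylated nitrogen bearing a substituted benzyl group, and compound 2, which carries the same kind of nitrogen, all bind; compound 4 has none of this. The step from compound 2 to compound 4 in this assay is expected to raise the number, by a 9.5-fold higher number from compound 2 to compound 4 (0.98 log units; beyond the scatter), with wide uncertainty. Compound 4 is estimated at 40 nM, in the range 6 nM to 300 nM.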

Compound 4, half-maximal inhibitory concentration: 840 nM
Beside the measured number, compound 4's estimate is 21-fold (1.32 log units) below it; the measured number lies above the stated range.
By their numbers in this assay, from the lowest: compound 2; then compounds 3 and 1 (each within the scatter of the next); then compound 4.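

In this assay, the change on the carbonyl carbon brings a 200-fold higher number from compound 2 to compound 4 (2.30 log units; beyond the scatter), a large step taken with the rest of the structure unchanged. The earlier compounds shown here offered no such single-place comparison, and this pair shows that binding depends strongly on what stands at this place on the shared core. A (3-methylphenyl)amino group, with its hydrogen-bond donor, is a poor replacement here for the group carrying the N-methyl and the 2-chlorobenzyl unit, but no measurement at hand explains why.

The step changes several things at once, since the N-methyl, the chlorine and the benzyl carbon all leave while the amino hydrogen enters, so the compounds shown cannot assign the size of the step to any one of these. From the compounds shown here alone, an N-methyl-(3-methylphenyl)amino group or a plain benzylamino group on the same carbonyl carbon would separate these parts, and how either would fare in this assay remains open.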